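Removing the remaining methyl from the shared core

The source may hold more compounds than are shown below. What is called first, only, known or untested is meant among the compounds shown, and "the series" means these compounds.

Compound 1 `CCCc1nc(C)c2c(C(C)C)cnc(Nc3cc[nH]n3)n12` and compound 2 `CCCc1nc(C)c2c(C)cnc(Nc3cc[nH]n3)n12` share one core. Compound 3 `CCCc1ncc2c(C)cnc(Nc3cc[nH]n3)n12` is built on the same core. In a functional assay for inhibition, with Homo sapiens as the target (a lower number here means a stronger inhibitor, a higher number a weaker inhibitor), compound 1 gives > 48000 nM, which is a limit of the assay. In this assay compound 2 likewise gives > 48000 nM, again a limit. Compound 2 therefore stands only at the limit of > 48000 nM in this assay, at which 2 of the 2 values shown sit. Within the data shown here, the single measured step that bears on the change, a step that the two limits leave unreadable from compound 1 to compound 2, has no readable size. The change to compound 3 is hydrogen in place of methyl on an aromatic carbon. No direction in this assay can be read from two limits, so compound 3 is expected to remain near the same limit. Compound 3 is estimated at 60000 nM, within 20000 nM to 200000 nM, an expected step that the limit leaves unreadable from compound 2 to compound 3.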

Compound 3, half-maximal inhibitory concentration: 39000 nM
For compound 3 the middle estimate is 1.5-fold (0.19 log units) above the measured one, and the stated range covers the measured number.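

Hydrogen in place of methyl on this aromatic carbon gives an at least 1.2-fold lower number from compound 2 to compound 3 (0.09 log units; that floor lies within the scatter). Compound 3 is therefore the only one of the three with a number rather than a limit in this assay, although the floor of this step cannot separate it from compound 2, and the step between compounds 1 and 2 cannot be read. The other two values are limits of the assay: the limit of > 48000 nM in this assay, at which 2 of the 3 values shown sit.

Still open, as far as these compounds go, is how far the true step from compound 2 extends. From the compounds shown here alone, it is also open whether an amine on this carbon, or a longer chain in place of propyl, would move the number.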